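The source may report more compounds than this note shows. Statements on the series, on what has been measured and on what is new or still open speak of the compounds shown alone.

Measured so far in a functional assay on FM3A cells (Homo sapiens) for inhibition, with FM3A (Mus musculus) as the target; on this read-out higher numbers stand for weaker inhibition and lower numbers for stronger inhibition:
Compound 1 `CC(O)n1cnc2c(N)nc(I)nc21` gives 452000 nM in this assay.
Compound 2 `Nc1nc(I)nc2c1ncn2OCCO` gives only a limit in this assay, > 500000 nM.

For the measured compounds named here, only one measured step joins these two: an at least 1.1-fold higher number from compound 1 to compound 2 (0.04 log units; that floor lies within the scatter), which changes the group on the aromatic nitrogen and ends at the limit of > 500000 nM in this assay, at which 1 of the 2 values shown sits, so it yields a floor rather than a number. Compound 2 therefore stands at the limit of this assay, with no value of its own on the numbers shown.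

Compound 3 `COc1nc(I)nc2c1ncn2OCCO` differs from compound 2 by methoxy in place of amino on an aromatic carbon. Going by the values given here, no measured step concerns this change: the single step available alters the substituent on the aromatic nitrogen and leaves the amino group untouched. With nothing to compare against, and with compound 2 itself at a limit, neither size nor direction of the step in this assay can be drawn from the data. Compound 3 is expected to remain at or beyond the limit, and its value is estimated at 600000 nM, between 200000 nM and 2000000 nM. The step that this estimate implies, a step that the limit leaves unreadable from compound 2 to compound 3, is expected to be small against a floor that is itself uncertain.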

Compound 3, half-maximal inhibitory concentration: > 500000 nM
Compound 3: a limit, no number; the forecaster's own chance of this, stated with the estimate: 80%; the middle value is on the limit's open side.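

Compound 3 gives only a limit in this assay, > 500000 nM. For the compounds shown here, compound 2 is also held at a limit, so no step between compound 2 and compound 3 can be read: the limit of > 500000 nM in this assay, at which 2 of the 3 values shown sit. The compounds shown leave open what methoxy in place of amino on an aromatic carbon does to inhibition when it is measured as a number.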